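Amide aryl variation on the shared core: compound 3

The compounds below may be only part of what the source reports. "The series", "measured", "known", "first", "only" and "open" are said of these compounds alone.

Measured so far:
compound 1 `O=C(Nc1cccc(-c2oc3cc(-c4ccc(F)cc4)ccc3c(=O)c2O)c1)c1ccc(Br)cc1`: 24000 nM
compound 2 `O=C(Nc1cccc(-c2oc3cc(-c4ccc(F)cc4)ccc3c(=O)c2O)c1)c1ccc([N+](=O)[O-])cc1`: 3970 nM

In a functional assay on MCF7 cells (Homo sapiens) for antiproliferative activity, read by CCK-8 assay, with a stated time of 72 h (a higher number here means a weaker inhibitor, a lower number a stronger inhibitor), compound 1 gives 24000 nM, the highest of the two numbers recorded. Within the data shown here, its only neighbour, compound 2, gives 3970 nM, and the step of a 6.0-fold lower number from compound 1 to compound 2 (0.78 log units; beyond the scatter) is the single measured step in the set. Compound 3 `O=C(Nc1cccc(-c2oc3cc(-c4ccc(F)cc4)ccc3c(=O)c2O)c1)c1ccc(-c2ccccc2)cc1` differs from compound 1 by phenyl in place of bromo on an aromatic carbon. The measured step is the only one that bears on this change, since it also alters the same aromatic carbon of compound 1, but it exchanges bromo for nitro rather than for phenyl, so it shows only that a replacement there can lower the number; it does not fix the size for phenyl. For compound 3 a modest step down is therefore expected, a 1.6-fold lower number from compound 1 to compound 3 (0.20 log units; within the scatter), with wide uncertainty in both directions. The estimate for compound 3 is 15000 nM, within a range of 4000 nM to 60000 nM.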

Compound 3, half-maximal inhibitory concentration: 38500 nM
Compound 3: middle estimate off by 2.6-fold (0.41 log units), on the low side; measured number inside the range.
By their numbers in this assay, from the lowest: compound 2; then compounds 1 and 3 (each within the scatter of the next).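

In this assay, phenyl, with six heavy atoms in place of the single atom of bromo, gives a 1.6-fold higher number from compound 1 to compound 3 (0.21 log units; within the scatter), so the two groups cannot be told apart at this aromatic carbon. Against nitro the same phenyl gives a 9.7-fold higher number from compound 2 to compound 3 (0.99 log units; beyond the scatter), which shows that the lower number of compound 2 does not follow from replacing bromo as such; among these three compounds, nitro alone stands apart. Nothing available here accounts for this difference between nitro and the other two groups.

Open, from the compounds shown here alone, is whether the lower number is particular to nitro or would also appear with a nitrile, an amine or a carboxylic acid on the same aromatic carbon. Also open, going by these compounds, is whether any group at this carbon can bring the number well below that of compound 2.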